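A few compounds are considered here, and "the series" means these few. Any claim that something is new, unique, unknown or untested is made for them only; others in the source may bear on it.

Compounds 1, 2 and 3 share one core and differ only in the group on the amide-type nitrogen: compound 1 `COc1ccc2c(=O)c(/C=C/C(=O)Nc3cc(C)ccc3C)coc2c1` carries a 2,5-dimethylphenyl, compound 2 `COc1ccc2c(=O)c(/C=C/C(=O)NCc3cccc(F)c3)coc2c1` a 3-fluorobenzyl, and compound 3 `COc1ccc(CNC(=O)/C=C/c2coc3cc(OC)ccc3c2=O)cc1` a 4-methoxybenzyl. In a functional assay on HeLa cells (Homo sapiens) for inhibition, read by MTT assay, with a stated time of 48 h (on this read-out lower numbers stand for stronger inhibition and higher numbers for weaker inhibition), compound 1 gives 58400 nM and compound 2 gives 17600 nM. For compound 3 the assay reports only a limit, > 100000 nM, so no number is known for it (the limit of > 100000 nM in this assay, at which 1 of the 3 values shown sits). Compound 4 `COc1ccc2c(=O)c(/C=C/C(=O)Nc3ccc(Cl)cc3)coc2c1` is not yet measured; it differs from compound 3 by 4-chlorophenyl in place of 4-methoxybenzyl on an amide-type nitrogen. The steps of an at least 1.7-fold higher number from compound 1 to compound 3 (0.23 log units; that floor lies within the scatter) and an at least 5.6-fold higher number from compound 2 to compound 3 (0.75 log units; beyond the scatter) both ran toward that limit, so the move back to a group bound directly to the nitrogen is expected to bring the number down. Compound 4 is therefore estimated at 50000 nM, between 15000 nM and 150000 nM, an expected step of an at least 2.0-fold lower number from compound 3 to compound 4 (0.30 log units; that floor lies within the scatter).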

Compound 4, half-maximal inhibitory concentration: > 100000 nM
Compound 4: only a limit was reported (the forecaster's own chance of this, stated with the estimate: 30%); middle value at least 2.0-fold (0.30 log units) away from the limit.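

Moving back to a ring bound directly to the amide-type nitrogen did not bring a number: compound 4, with its 4-chlorophenyl, reaches only a limit (> 100000 nM). The change from the 3-fluorobenzyl gives an at least 5.6-fold higher number from compound 2 to compound 4 (0.75 log units; beyond the scatter) and is a clear loss, whereas the change from the 2,5-dimethylphenyl gives an at least 1.7-fold higher number from compound 1 to compound 4 (0.23 log units; that floor lies within the scatter) and does not separate the two. The step from compound 3 cannot be read, as both ends are limits: the limit of > 100000 nM in this assay, at which 2 of the 4 values shown sit.

Still open, as far as these compounds go, is which part of the 4-chlorophenyl matters, the chlorine or the missing chain carbon; a 4-chlorobenzyl or a plain phenyl on the same nitrogen would separate these.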